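From 3,5-Dichlorophenyl to 3,5-Dimethoxyphenyl: An Expected Drop

The source may hold more compounds than are shown below. What is called first, only, known or untested is meant among the compounds shown, and "the series" means these compounds.

Going by the values given here, compound 3 `Cc1nc(-c2cccc(F)c2)c(C(=O)N2CCN(c3cc(Cl)cc(Cl)c3)CC2)o1` gives 40.7% in an ADME assay on microsomes from liver (Mus musculus) for metabolic stability, read by LC-MS, with a stated time of 1 h, tested at 5 uM (a lower number here means that less of the compound is left, a higher number that more of the compound is left), and stands highest of the three numbers so far, beyond the scatter from both of the others, compound 1 `COc1cc(OC)cc(N2CCN(C(=O)c3oc(C)nc3-c3ccccc3F)CC2)c1` and compound 2 `COc1cc(OC)cc(N2CCN(C(=O)c3oc(C)nc3-c3ccc(F)cc3)CC2)c1` in this series. Compound 4 `COc1cc(OC)cc(N2CCN(C(=O)c3oc(C)nc3-c3cccc(F)c3)CC2)c1` has not been measured yet. It differs from compound 3 in one place (3,5-dimethoxyphenyl in place of 3,5-dichlorophenyl on an amine nitrogen in a ring) on an amine nitrogen in a ring, where 3,5-dimethoxyphenyl takes the place of 3,5-dichlorophenyl.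

Among the compounds with values here, no measured step shows this swap directly. Within the data shown here, the only step between close neighbours (a number 11 percentage points lower from compound 1 to compound 2 (beyond the scatter)) concerns the fluorophenyl group and is modest. Even so, compound 1 at 16.6% and compound 2 at 5.6% already carry the same 3,5-dimethoxyphenyl, so a large drop in this assay is expected, well beyond the scatter. Compound 4 keeps the fluorophenyl group of compound 3, which neither compound 1 nor compound 2 has, so some uncertainty remains and the range stays wide. The estimated change is a number 29.7 percentage points lower from compound 3 to compound 4 (beyond the scatter) in this read-out. For compound 4 the expected value is 11% with an estimated range from 4% to 24% at the end of the hour.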

Compound 4, percent of the compound remaining: 11.6%
Beside the measured number, compound 4's estimate is 0.6 percentage points below it; low and high end bracket the measured number.
By their numbers in this assay, from the lowest: compounds 2, 4 and 1 (each within the scatter of the next, the first and the last beyond it); then compound 3.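

The swap on the amine nitrogen in a ring can now be read directly: in this assay, 3,5-dimethoxyphenyl in place of 3,5-dichlorophenyl gives a number 29.1 percentage points lower from compound 3 to compound 4 (beyond the scatter), with the rest of the molecule unchanged, so this position clearly matters for how much compound is left after the hour. The fluorine changes on the other phenyl group are smaller here: 3-fluorophenyl in place of 4-fluorophenyl gives a number 6 percentage points higher from compound 2 to compound 4 (within the scatter), and 3-fluorophenyl in place of 2-fluorophenyl gives a number 5 percentage points lower from compound 1 to compound 4 (within the scatter), although the step of a number 11 percentage points lower from compound 1 to compound 2 (beyond the scatter) shows that the fluorine's place is not always without effect. Nothing available here explains why the swap has a step of this size.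

Among the compounds shown, 3,5-dichlorophenyl occurs only with 3-fluorophenyl, so it remains open whether the swap would give a similar step with 2-fluorophenyl or 4-fluorophenyl. Going by these compounds alone, with only two groups seen at this position, it also remains open where others, such as 3,5-dimethylphenyl or 3-chlorophenyl, would fall in this read-out.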